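The source may report more compounds than this note shows. Statements on the series, on what has been measured and on what is new or still open speak of the compounds shown alone.

In an assay (brain) for inhibition of Fatty-acid amide hydrolase 1 (Mus musculus), with stated times of 20 min and 15 min (on this read-out lower numbers stand for stronger inhibition and higher numbers for weaker inhibition), compound 1, `CCCCNC(=O)Oc1cccc(-n2ccc(C(N)=O)c2)c1`, gives 240 nM, and compound 2, `NC(=O)c1ccn(-c2cccc(OC(=O)NCCOCCOc3ccccc3)c2)c1`, gives 87 nM. Among the measured compounds shown here, compound 2 thus stands lowest of the two numbers known so far, its nearest neighbour being compound 1; the one step that connects them, a 2.8-fold lower number from compound 1 to compound 2 (0.44 log units; beyond the scatter), lies beyond the scatter and came with the lengthening of the chain on the carbamate side of the shared core.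

Compound 3, `NC(=O)c1ccn(-c2cccc(OC(=O)NCCOCCOc3ccccc3F)c2)c1`, carries a single further change on that chain's distal ring: fluoro in place of hydrogen on an aromatic carbon, so that the phenoxy of compound 2 becomes a 2-fluorophenoxy. For the measured compounds named here, no measured pair speaks to this change. Going by the values given here, the step from compound 1 to compound 2 concerned the chain itself, not a substituent on its terminal ring, and it is the only step in hand. With nothing to suggest a shift in either direction, compound 3 is expected to sit close to compound 2 in this assay, within the scatter, as a 1.1-fold lower number from compound 2 to compound 3 (0.04 log units; within the scatter). The estimate for compound 3 is therefore 80 nM, with a range from 35 nM to 180 nM.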

Compound 3, half-maximal inhibitory concentration: 69 nM
The estimate for compound 3 lay 1.2-fold (0.06 log units) above the measured number; low and high end bracket the measured number.
By their numbers in this assay, from the lowest: compounds 3 and 2 (each within the scatter of the next); then compound 1.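

In this assay, among the compounds shown here, the step of a 1.3-fold lower number from compound 2 to compound 3 (0.10 log units; within the scatter) is the first reading of a change on the terminal ring, whereas the earlier step concerned the chain itself. At this place, on an aromatic carbon ortho to a large group, the 2-fluorophenoxy of compound 3 and the phenoxy of compound 2 cannot be told apart on this read-out, since the two numbers lie within the scatter of each other. So a single fluoro at this position gives no measurable signal in either direction, and no accompanying measurement bears on why that should be so.

The compounds shown leave open whether a group other than fluoro, such as chloro, methoxy, trifluoromethyl or an amine, would give a number beyond the scatter at this same place. They also leave open whether the same fluoro would read any differently elsewhere on the ring, and whether a longer chain between the carbamate and the 2-fluorophenoxy would keep the two phenoxy forms level.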